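A few compounds are considered here, and "the series" means these few. Any claim that something is new, unique, unknown or untested is made for them only; others in the source may bear on it.

Compound 1 `Cc1ccc2[nH]c(-c3ccc(-c4ccc(-c5ccc(N(C)C)cc5)cc4)cc3)nc2c1`: 4230 nM
Compound 2 `COc1cc(-c2ccc(-c3ccc(-c4nc5cc(C)ccc5[nH]4)cc3)cc2)cc(OC)c1OC`: 2370 nM
Compound 3 `Fc1ccc(-c2ccc(-c3ccc(-c4nc5ccccc5[nH]4)cc3)cc2)cc1`: 39300 nM

All three values come from a functional assay on HOP-62 cells (Homo sapiens) for inhibition, read by sulforhodamine B assay; on this read-out lower numbers stand for stronger inhibition of growth and higher numbers for weaker inhibition of growth. Compound 3, at 39300 nM, has the highest number of the three, and it stands beyond the scatter from both of the others, so it is the weakest inhibitor of growth in this small set. Compound 1 and compound 2 lie within the usual scatter of each other. The next compound, compound 4 `Oc1ccc(-c2ccc(-c3ccc(-c4nc5ccccc5[nH]4)cc3)cc2)cc1`, has not yet been measured. It keeps the frame of compound 3 and carries hydroxy in place of fluoro on an aromatic carbon.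

Among the measured compounds shown here, no two measured compounds differ in one place only, so no measured step speaks directly to this change. For the measured compounds named here, the only guide is indirect: compound 1 at 4230 nM and compound 2 at 2370 nM carry other groups at that end of the molecule and differ from compound 3 elsewhere too, yet both sit well lower. A moderate step towards a lower number in this assay is therefore expected, though one within the scatter would be no surprise. The expected step is a 3.3-fold lower number from compound 3 to compound 4 (0.52 log units; beyond the scatter). For compound 4 the estimated value is 12000 nM, with an expected range of 3000 nM to 40000 nM.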

Compound 4, concentration for 50% growth inhibition: 47200 nM
The estimate for compound 4 lay 3.9-fold (0.59 log units) below the measured number, outside the stated range (above it).
By their numbers in this assay, from the lowest: compounds 2 and 1 (each within the scatter of the next); then compounds 3 and 4 (each within the scatter of the next).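

Among the compounds shown here, exchanging fluoro for hydroxy on an aromatic carbon, para to a large group, gives the first direct reading of this position, and in this assay the 4-fluorophenyl to 4-hydroxyphenyl change comes to a 1.2-fold higher number from compound 3 to compound 4 (0.08 log units; within the scatter) on the shared core. A group with one hydrogen-bond donor and one hydrogen-bond acceptor thus stands where the fluoro had none, and this read-out does not separate the two compounds. No measurement shown here accounts for this result.

As far as these compounds go, whether a carboxylic acid or a primary amine at this position would also stay within the scatter of compound 3 remains open. From the compounds shown here alone, compound 1 and compound 2 each differ from compound 3 in more than one place, so it also remains open whether the dimethylamino group of compound 1, the methoxy groups of compound 2 or the methyl group that both carry on the core would, taken alone, shift the number in this assay for this series.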